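Benzyl in place of methyl on the piperazine nitrogen

A few compounds are considered here, and "the series" means these few. Any claim that something is new, unique, unknown or untested is made for them only; others in the source may bear on it.

Of the compounds shown here, three sharing one core have been tested in a functional assay on the whole organism (strain CD1) with Mus musculus as the target, in the maximal electroshock model, with a stated time of 4 h; on this read-out higher numbers stand for an effect only at larger amounts of compound and lower numbers for an effect already at smaller amounts. Compound 1 `O=C1NC(c2ccccc2)(c2ccccc2)C(=O)N1CN1CCN(c2ccccc2)CC1` gives 100 mg/kg, compound 2 `O=C1NC(c2ccccc2)(c2ccccc2)C(=O)N1CN1CCN(c2ccccc2F)CC1` gives 30 mg/kg, and compound 3 `CN1CCN(CN2C(=O)NC(c3ccccc3)(c3ccccc3)C2=O)CC1` gives 10 mg/kg. Compound 3 therefore stands lowest of the three, with steps to both others that lie beyond the scatter: a 10-fold lower number from compound 1 to compound 3 (1.00 log units; beyond the scatter) and a 3.0-fold lower number from compound 2 to compound 3 (0.48 log units; beyond the scatter). The step of a 3.3-fold lower number from compound 1 to compound 2 (0.52 log units; beyond the scatter) is the only other one recorded.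

Compound 4 `O=C1NC(c2ccccc2)(c2ccccc2)C(=O)N1CN1CCN(Cc2ccccc2)CC1` has not yet been measured. It differs from compound 3 in one place: phenyl in place of hydrogen on a saturated chain carbon bound to an amine nitrogen in a ring. Within the data shown here, the steps that bear on this change are those in which an aromatic group stood directly on the amine nitrogen in the ring, in compound 1 and compound 2, and both gave higher numbers than compound 3. In compound 4 the phenyl is held one bond further out, on the saturated chain carbon, so the reach of those steps to this case is only partial. A rise of modest size is nonetheless expected, smaller than either measured step. Compound 4 is estimated at 20 mg/kg, within 8 mg/kg to 60 mg/kg, which corresponds to an expected step of a 2.0-fold higher number from compound 3 to compound 4 (0.30 log units; within the scatter).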

Compound 4, minimum effective dose: 100 mg/kg
Compound 4: middle estimate off by 5.0-fold (0.70 log units), on the low side, and the stated range ends below it.
By their numbers in this assay, from the lowest: compound 3; then compound 2; then compounds 1 and 4 (each within the scatter of the next).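

In this assay, the change from methyl to benzyl gives a 10-fold higher number from compound 3 to compound 4 (1.00 log units; beyond the scatter) and so shows that an aromatic ring need not stand directly on the amine nitrogen in the ring for the number to rise: with the phenyl held on the saturated chain carbon, the benzyl group shows no change at the digits printed from compound 1 to compound 4 (within the scatter) and gives nothing back relative to the directly attached phenyl. Compound 4 also lies above the fluorinated compound, with a 3.3-fold higher number from compound 2 to compound 4 (0.52 log units; beyond the scatter) on replacing 2-fluorophenyl by benzyl. Among the four compounds, methyl on this nitrogen thus gives the lowest number and all three groups carrying an aromatic ring give higher ones, with no compound going against this, but nothing available explains the behaviour of the benzyl group.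

Going by these compounds, whether a plain hydrogen, an ethyl group or a longer chain ending in an amine or a carboxylic acid on this nitrogen would stay with methyl or join benzyl remains open. Also open, on these data alone, is whether 2-fluorobenzyl would repeat, on benzyl, what fluoro did on phenyl with a 3.3-fold lower number from compound 1 to compound 2 (0.52 log units; beyond the scatter) in that comparison.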